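This account rests on a few compounds, and the source may have more. Where it says the series, first, only, none or still open, it means among the compounds named here.

Measured compounds in a functional assay on ECa-109 cells for inhibition, with ECa-109 cell line (Homo sapiens) as the target, read by sulforhodamine B assay; a higher number here means a weaker inhibitor, a lower number a stronger inhibitor:
Compound 1 `O=C1C=C(NCc2ccccc2)C(=O)c2c1nc1n2[C@H]2OC[C@@H](O)[C@H]2OC1` gives > 8000 nM, which is a limit of the assay and not a number.
Compound 2 `O=C1C(Nc2ccccc2F)=CC(=O)c2c1nc1n2[C@H]2OC[C@@H](O)[C@H]2OC1` gives 2660 nM.

Compound 1 thus stands at the limit of > 8000 nM in this assay, at which 1 of the 2 values shown sits. Compound 3 `CCOc1ccccc1NC1=CC(=O)c2nc3n(c2C1=O)[C@H]1OC[C@@H](O)[C@H]1OC3` differs from compound 1 by 2-ethoxyphenyl in place of benzyl on an amine nitrogen. Among the compounds with values here, no measured step connects these two compounds, so the size of the change is only a guess. A move toward stronger inhibition seems likely because compound 2, which also carries an aromatic ring directly on the amine nitrogen, gives 2660 nM. The expected step is an at least 2.0-fold lower number from compound 1 to compound 3 (0.30 log units; that floor lies within the scatter), beyond the usual scatter. Compound 3 is therefore estimated at 4000 nM, in the range 1500 nM to 12000 nM.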

Compound 3, half-maximal inhibitory concentration: 4630 nM
For compound 3 the middle estimate is 1.2-fold (0.06 log units) below the measured one, within the range that was stated.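

Putting 2-ethoxyphenyl in place of benzyl on the amine nitrogen brings the core of compound 1 to a measurable value in this assay, with an at least 1.7-fold lower number from compound 1 to compound 3 (0.23 log units; that floor lies within the scatter). Compound 1 has only a limit and not a number, so the true size of this step remains unknown: the limit of > 8000 nM in this assay, at which 1 of the 3 values shown sits.

The compounds shown do not separate the contribution of the ethoxy group from that of removing the benzyl carbon between ring and nitrogen. Going by these compounds, how a plain phenyl, a 2-methoxyphenyl or a longer alkoxy chain would behave on this amine nitrogen also remains open.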